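Swapping the pyridin-2-yl group of compound 3

The source may report more compounds than this note shows. Statements on the series, on what has been measured and on what is new or still open speak of the compounds shown alone.

Compound 1 `N#Cc1c(Nc2ccccc2)nc(SCc2nc3ccccc3[nH]2)nc1-c1ccccc1`: 2.9 nM
Compound 2 `CCNc1nc(SCc2nc3ccccc3[nH]2)nc(-c2ccccc2)c1C#N`: 7.35 nM
Compound 3 `N#Cc1c(Nc2ccccn2)nc(SCc2nc3ccccc3[nH]2)nc1-c1ccccc1`: 7.35 nM

In a functional assay on KB cells (Homo sapiens) for cytotoxicity, read by MTT assay, with a stated time of 3 days (on this read-out lower numbers stand for stronger inhibition and higher numbers for weaker inhibition), compound 3 stands level with compound 2 and the two share the highest number of the three, while compound 1 holds the lowest. Compound 4 `N#Cc1c(NC(N)=S)nc(SCc2nc3ccccc3[nH]2)nc1-c1ccccc1`, not yet measured, has a group of 3 heavy atoms (1 carbon, 1 nitrogen, 1 sulfur; no ring) in place of a group of 6 heavy atoms (5 carbon, 1 nitrogen; one six-membered aromatic ring with 1 hetero atom), on a nitrogen on an aromatic ring relative to compound 3. Among the compounds with values here, three measured changes on that nitrogen bear on this: a 2.5-fold higher number from compound 1 to compound 2 (0.40 log units; beyond the scatter) and a 2.5-fold higher number from compound 1 to compound 3 (0.40 log units; beyond the scatter) are modest and no change at the digits printed from compound 2 to compound 3 (within the scatter) is no step at all. Within the data shown here, no measured compound carries the entering group, so the direction stays open. What is expected is a 1.1-fold higher number from compound 3 to compound 4 (0.04 log units; within the scatter) and thus no clear step in this assay in either direction. Compound 4 is estimated at 8 nM (expected range 3 nM to 25 nM).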

Compound 4, half-maximal inhibitory concentration: 3.2 nM
Estimate against measurement, compound 4: 2.5-fold (0.40 log units) above; the range from low to high includes it.
By their numbers in this assay, from the lowest: compounds 1 and 4 (each within the scatter of the next); then compounds 2 and 3 (each within the scatter of the next).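

In this assay the group of 3 heavy atoms on this nitrogen gives a 2.3-fold lower number from compound 3 to compound 4 (0.36 log units; beyond the scatter) and a 2.3-fold lower number from compound 2 to compound 4 (0.36 log units; beyond the scatter) while a 1.1-fold higher number from compound 1 to compound 4 (0.04 log units; within the scatter) remains within the scatter. A ring on this nitrogen is therefore not needed to reach the level of compound 1, and the ethyl of compound 2 had not shown this. Nothing measured here explains these steps. Whether the sulfur matters stays open, since neither a urea, with oxygen in its place, nor a longer alkyl chain on this nitrogen appears among these compounds.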